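One Inverted Ring Carbon in a Silyl Ether Series

The source may hold more compounds than are shown below. What is called first, only, known or untested is meant among the compounds shown, and "the series" means these compounds.

Within the data shown here, in a functional assay on L929 cells (Mus musculus) for antiproliferative activity, read by MTT assay (on this read-out higher numbers stand for weaker inhibition and lower numbers for stronger inhibition), compound 1 `C[C@H]1[C@H](O[Si](c2ccccc2)(c2ccccc2)C(C)(C)C)C[C@]2(C)CC(=O)C[C@]12C` gives 14300 nM as the only exact number so far. In this assay compound 2 `C[C@H]1C(=O)C[C@]2(C)CC3(C[C@]12C)OCC(C)(C)CO3` reads > 150000 nM and that value is a limit of the assay. Among the measured compounds shown here, compound 3 `C[C@@H]1[C@H](O[Si](c2ccccc2)(c2ccccc2)C(C)(C)C)C[C@]2(C)CC(=O)C[C@]12C` has the same atoms and bonds as compound 1 (the two compounds have the same atoms and bonds and differ only in configuration as drawn: 1 of 4 stereo elements differ; a stereocentre at a saturated ring carbon is drawn R in compound 1 and S in compound 3) with a stereocentre at a saturated ring carbon drawn S instead of R. No measured pair shows what such a change does in this assay so no shift beyond the scatter is expected. The estimated step of a 1.3-fold higher number from compound 1 to compound 3 (0.10 log units; within the scatter) is therefore small. The expected value for compound 3 is 18000 nM within an estimated range of 6000 nM to 60000 nM in this test.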

Compound 3, half-maximal inhibitory concentration: 35700 nM
Compound 3: middle estimate off by 2.0-fold (0.30 log units), on the low side, and the stated range covers the measured number.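

In this assay, inverting the saturated ring carbon gives a 2.5-fold higher number from compound 1 to compound 3 (0.40 log units; beyond the scatter). Among these compounds, this is the first pair to show that configuration at this position alone can shift the read-out beyond the scatter, though the step is modest and compound 3 still gives an exact number rather than a limit. The shift toward weaker inhibition can be tied to a single structural difference: the fact that compounds 1 and 3 differ only in the configuration as drawn

The compounds shown leave open whether the same inversion has a similar effect when the silyl ether gives way to a free hydroxyl or an acetate ester.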